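A chloro added to two related cores

This account rests on a few compounds, and the source may have more. Where it says the series, first, only, none or still open, it means among the compounds named here.

compound 1, `ClCc1ccc(Cn2cnc3c(Cl)ncnc32)cc1`, 7410 nM
compound 2, `ClCc1cccc(Cn2cnc3ncnc(Cl)c32)c1`, > 100000 nM
compound 3, `ClCc1ccc(Cn2cnc3c(Cl)nc(Cl)nc32)cc1`, 7410 nM

In a functional assay on U-251 cells (Homo sapiens) for cytotoxicity, read by sulforhodamine B assay, with a stated time of 48 h (on this read-out higher numbers stand for lower toxicity in this test and lower numbers for higher toxicity in this test), compound 1 gives 7410 nM. Compound 3 carries chloro in place of hydrogen on an aromatic carbon, and this gave no change at the digits printed from compound 1 to compound 3 (within the scatter). For compound 2 the value > 100000 nM is a limit of this assay, not a number. The difference between the core of compound 1 and the core of compound 2 is not broken down here. Compound 4, `ClCc1cccc(Cn2cnc3nc(Cl)nc(Cl)c32)c1`, is not yet measured and differs from compound 2 by chloro in place of hydrogen on an aromatic carbon, the same change as from compound 1 to compound 3. In this assay the expected step is a number no higher from compound 2 to compound 4 (the limit leaves the size open) because the same change gave no change at the digits printed from compound 1 to compound 3 (within the scatter), and compound 2 already sits at the limit of > 100000 nM in this assay, at which 1 of the 3 values shown sits. Compound 4 is therefore estimated at 100000 nM, between 30000 nM and 300000 nM, with a good chance that this assay again reports only a limit.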

Compound 4, concentration lethal to 50% of the cells: 5120 nM
Compound 4: middle estimate off by 20-fold (1.29 log units), on the high side, outside the stated range (below it).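

On the core of compound 2, chloro in place of hydrogen on an aromatic carbon gave an at least 19-fold lower number from compound 2 to compound 4 (1.29 log units; beyond the scatter) in this assay. The change therefore does not carry from one core to the other at a single size: the same change on two cores in this assay, no change at the digits printed (within the scatter) from compound 1 to compound 3 and an at least 19-fold lower number (1.29 log units; beyond the scatter) from compound 2 to compound 4, at least 19-fold (1.29 log units) apart, beyond the scatter of two such steps

For compound 2, > 100000 nM is a limit of the assay and not a number, and these two pairs do not show why the steps differ.

The compounds shown carry only hydrogen or chloro on that aromatic carbon, so it remains open how an amine or a methoxy group there would fare on either core. From the compounds shown here alone, whether a third core would follow either step also remains open.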